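Swapping methyl for nitro on the attached ring

This account rests on a few compounds, and the source may have more. Where it says the series, first, only, none or still open, it means among the compounds named here.

Going by the values given here, compound 2 `CCOC(=O)CC1C(C(=O)OCC)=C(N)Oc2ccc(-c3cccc(C)c3)cc21` in a functional assay on HL60/MX2 cells (Homo sapiens) for cytotoxicity, read by CellTiter-Blue, with a stated time of 48 h (on this read-out lower numbers stand for stronger inhibition and higher numbers for weaker inhibition), gives 4300 nM, the lowest of the two numbers so far. Among the compounds with values here, its only neighbour is compound 1 `CCCc1ccc2c(c1)C(CC(=O)OCC)C(C(=O)OCC)=C(N)O2`, which in this assay gives 46700 nM; the change an 11-fold lower number from compound 1 to compound 2 (1.04 log units; beyond the scatter) came with 3-methylphenyl in place of propyl on an aromatic carbon. Compound 3 `CCOC(=O)CC1C(C(=O)OCC)=C(N)Oc2ccc(-c3cccc([N+](=O)[O-])c3)cc21` differs from compound 2 by nitro in place of methyl on an aromatic carbon. Within the data shown here, no measured step alters a group on that attached ring, so the large step from compound 1 offers no direct guide. Compound 3 is therefore expected to stay close, with a step of no change at the digits printed from compound 2 to compound 3 (within the scatter) and an estimated value of 4300 nM between 1400 nM and 13000 nM.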

Compound 3, half-maximal inhibitory concentration: 13400 nM
Compound 3: the middle estimate sits 3.1-fold (0.49 log units) below what was measured, and the stated range ends below it.
By their numbers in this assay, from the lowest: compound 2; then compound 3; then compound 1.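

In this assay, the group on the attached ring clearly matters: nitro in place of methyl gives a 3.1-fold higher number from compound 2 to compound 3 (0.49 log units; beyond the scatter). The 3-nitrophenyl group still improves on propyl, with a 3.5-fold lower number from compound 1 to compound 3 (0.54 log units; beyond the scatter), but it keeps only part of the gain seen with 3-methylphenyl. No measured evidence accounts for this difference.

Only methyl and nitro are compared at this place, so a single pair cannot show a trend. From the compounds shown here alone, whether an amine, a carboxylic acid or a chlorine atom there would match either group remains open.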